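This account rests on a few compounds, and the source may have more. Where it says the series, first, only, none or still open, it means among the compounds named here.

Compound 1 `CCC/N=C1\S/C(=C\c2ccc(O)cn2)C(=O)N1c1ccccc1C`: 2.8 mL.min-1.g-1
Compound 2 `CCC/N=C1\S/C(=C\c2ccc(O)cc2)C(=O)N1c1ccccc1C`: 2.4 mL.min-1.g-1
Compound 3 `CCC/N=C1\S/C(=C\c2ccc(O)c(C(F)(F)F)c2)C(=O)N1c1ccccc1C`: 1 mL.min-1.g-1

In an ADME assay on microsomes from liver (Homo sapiens) for metabolic stability, read by HPLC, with a stated time of 30 min, tested at 0.5 uM (a higher number here means faster removal of the compound, a lower number slower removal), compound 3 stands lowest of the three, at 1 mL.min-1.g-1. Compound 4 `CCC/N=C1\S/C(=C\c2ccc(O)c(Br)c2)C(=O)N1c1ccccc1C` differs from it in one place: bromo in place of trifluoromethyl on an aromatic carbon. This is bromo in place of trifluoromethyl on an aromatic carbon, ortho to a hydroxy group. The most relevant evidence is a 2.4-fold lower number from compound 2 to compound 3 (0.38 log units; beyond the scatter), a modest step beyond the scatter made at this same position. By contrast, a 1.2-fold lower number from compound 1 to compound 2 (0.07 log units; within the scatter) lies within the scatter and involves a different change. For the measured compounds named here, no measured compound carries bromo, so the data offer only a rough guide. Compound 4 is expected to stay close to compound 3, with no step beyond the scatter. The expected step is a 1.3-fold higher number from compound 3 to compound 4 (0.11 log units; within the scatter). Compound 4 is estimated at 1.3 mL.min-1.g-1, within an expected range of 0.7 mL.min-1.g-1 to 2.4 mL.min-1.g-1.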

Compound 4, intrinsic clearance in microsomes: 1.6 mL.min-1.g-1
For compound 4 the middle estimate is 1.2-fold (0.09 log units) below the measured one; the measured number falls inside the stated range.
By their numbers in this assay, from the lowest: compounds 3, 4, 2 and 1 (each within the scatter of the next, the first and the last beyond it).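

In this assay, bromo in place of trifluoromethyl gives a 1.6-fold higher number from compound 3 to compound 4 (0.20 log units; within the scatter), so at this position the two groups cannot be told apart. Bromo in place of hydrogen gives a 1.5-fold lower number from compound 2 to compound 4 (0.18 log units; within the scatter), unlike the earlier trifluoromethyl step, and 3-bromo-4-hydroxyphenyl in place of 5-hydroxypyridin-2-yl gives a 1.8-fold lower number from compound 1 to compound 4 (0.24 log units; within the scatter). No measurement on these compounds bears on what lies behind these numbers. Still open, on these data alone, is whether an amine or a carboxylic acid at this position would give a step beyond the scatter, and whether bromo would act the same on the 5-hydroxypyridin-2-yl ring.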